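Amide variation on the bis-sulfonamide piperidine core

The source may report more compounds than this note shows. Statements on the series, on what has been measured and on what is new or still open speak of the compounds shown alone.

Measured so far:
- compound 1 `CCN(CC)S(=O)(=O)c1ccc(S(=O)(=O)N2CCC[C@@H](C(=O)N(C)C(C)C)C2)cc1`: 1400 nM
- compound 2 `CCN(CC)S(=O)(=O)c1ccc(S(=O)(=O)N2CCC[C@@H](C(=O)N3CCC(c4nc(C(C)C)no4)CC3)C2)cc1`: 30 nM

In a functional assay on MIA PaCa-2 cells (Homo sapiens) for inhibition, read by MTT assay, with a stated time of 3 days (a higher number here means a weaker inhibitor, a lower number a stronger inhibitor), compound 1 gives 1400 nM, the higher of the two numbers, while compound 2 gives 30 nM, a difference beyond the scatter. Compound 3 `CCN(CC)S(=O)(=O)c1ccc(S(=O)(=O)N2CCC[C@@H](C(=O)NC3COC3)C2)cc1` keeps the core of compound 1 and carries (oxetan-3-yl)amino in place of isopropyl(methyl)amino on a carbonyl carbon. Among the compounds with values here, no measured pair covers this exchange of one small amide substituent for another. The step from compound 1 to compound 3 is expected to be small, toward a somewhat higher number, a 1.8-fold higher number from compound 1 to compound 3 (0.25 log units; within the scatter). Compound 3 is therefore estimated at 2500 nM, with a range from 800 nM to 8000 nM.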

Compound 3, half-maximal inhibitory concentration: 900 nM
Beside the measured number, compound 3's estimate is 2.8-fold (0.44 log units) above it; the range from low to high includes it.
By their numbers in this assay, from the lowest: compound 2; then compounds 3 and 1 (each within the scatter of the next).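

In this assay the exchange of isopropyl(methyl)amino for (oxetan-3-yl)amino on a carbonyl carbon reads as a 1.6-fold lower number from compound 1 to compound 3 (0.19 log units; within the scatter) and so does not separate the two amides. At this place, a four-membered non-aromatic ring with a hydrogen-bond donor and acceptor can thus enter at an equal heavy-atom count with no difference outside the scatter. No supporting measurement bears on this result.

From the compounds shown here alone, whether cyclobutylamino, which keeps the ring but lacks its oxygen, would read the same on this carbonyl carbon stays open. Also open, going by these compounds, is which part of the larger amine of compound 2 sets it apart from compound 1.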